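A few compounds are considered here, and "the series" means these few. Any claim that something is new, unique, unknown or untested is made for them only; others in the source may bear on it.

The measured compounds in a functional assay on HepG2 cells (Homo sapiens) for inhibition, read by MTT assay, with a stated time of 72 h; on this read-out higher numbers stand for weaker inhibition and lower numbers for stronger inhibition:
compound 1 `CN(C(=O)NC(=O)c1cccc(C(F)(F)F)c1)c1nc(C(F)(F)F)c(C(=O)N/N=C/c2ccccc2C(F)(F)F)s1` gives 10.4 ug/mL;
compound 2 `CN(C(=O)NC(=O)c1ccc([N+](=O)[O-])cc1)c1nc(C(F)(F)F)c(C(=O)N/N=C/c2ccc([N+](=O)[O-])cc2)s1` gives 12.3 ug/mL;
compound 3 `CN(C(=O)NC(=O)c1ccc(F)c(F)c1)c1nc(C(F)(F)F)c(C(=O)N/N=C/c2ccccc2C(F)(F)F)s1` gives 10.4 ug/mL.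

Compound 3 stands level with compound 1, and together they hold the lowest of the three numbers; compound 2 gives a slightly higher number, but that gap is within the scatter of repeated measurements, so the three compounds effectively share one level of activity in this assay. Among the compounds with values here, the only single-point change among them, no change at the digits printed from compound 1 to compound 3 (within the scatter), concerns the group on the carbonyl carbon and leaves the rest of the molecule untouched.

Compound 4 `CN(C(=O)NC(=O)c1ccc(F)c(F)c1)c1nc(C(F)(F)F)c(C(=O)N/N=C/c2ccc([N+](=O)[O-])cc2)s1` is the next member of this set. Compared with compound 3, (4-nitrophenyl in place of 2-(trifluoromethyl)phenyl on a carbon with a double bond to nitrogen). Within the data shown here, no measured step changes this position alone, so the step from compound 1 to compound 3 bears on it only indirectly, showing that swapping an aromatic group elsewhere produced no movement. Compound 2 already carries the 4-nitrophenyl group at the same place, together with a different group on the carbonyl carbon, and its value lies within the scatter of compound 3. From this, no step beyond the scatter is expected: a 1.1-fold higher number from compound 3 to compound 4 (0.04 log units; within the scatter). Compound 4 is therefore estimated at 11.5 ug/mL, with a range from 6 ug/mL to 23 ug/mL.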

Compound 4, half-maximal inhibitory concentration: 6.23 ug/mL
Estimate against measurement, compound 4: 1.8-fold (0.27 log units) above; measured number inside the range.
By their numbers in this assay, from the lowest: compounds 4, 1, 3 and 2 (each within the scatter of the next).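

In this assay, within the data shown here, the change at the carbon with a double bond to nitrogen can now be read on its own for the first time: the swap of 2-(trifluoromethyl)phenyl for 4-nitrophenyl gives a 1.7-fold lower number from compound 3 to compound 4 (0.22 log units; within the scatter) and so shows no real shift at this place. The carbonyl carbon also gains a second reading, now with 4-nitrophenyl at the other varied place, and 3,4-difluorophenyl in place of 4-nitrophenyl gives a 2.0-fold lower number from compound 2 to compound 4 (0.30 log units; within the scatter) and so, though close to the limit of the scatter, also shows no real shift. No measured evidence here explains why these numbers sit where they do.

As far as these compounds go, all the groups varied at these two places are substituted phenyl rings, so it remains open whether an amine, a carboxylic acid or a longer chain at the carbon with a double bond to nitrogen would move the number beyond the scatter. An unsubstituted phenyl ring at either place would also show whether the substituents on these rings matter at all.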